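The source may hold more compounds than are shown below. What is called first, only, known or untested is meant among the compounds shown, and "the series" means these compounds.

Compounds measured so far:
compound 1 `COc1ccc(-c2nc3cc(/C=C4\SC(=O)N(CC(=O)N5CCOCC5)C4=O)ccc3[nH]2)cc1OC` with 3320 nM
compound 2 `COc1cc(-c2nc3cc(/C=C4\SC(=O)N(CC(=O)N5CCCCC5)C4=O)ccc3[nH]2)cc(OC)c1OC` with 3650 nM
compound 3 `COc1cc(CN2C(=O)S/C(=C\c3ccc4[nH]c(-c5cc(OC)c(OC)c(OC)c5)nc4c3)C2=O)cc(OC)c1OC` with 980 nM

All three were tested in a functional assay on HT-1080 cells (Homo sapiens) for inhibition, read by MTT assay, with a stated time of 48 h; on this read-out lower numbers stand for stronger inhibition and higher numbers for weaker inhibition. On this read-out compound 3 gives the lowest number of the three; compound 1 lies above it by a margin beyond the scatter, and compound 2 lies further above it, also beyond the scatter. Going by the values given here, the only single-point step among them is a 3.7-fold lower number from compound 2 to compound 3 (0.57 log units; beyond the scatter), and that step concerns the group on the ring nitrogen, not the aryl group on the shared core.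

Compound 4 `COc1ccc(-c2nc3cc(/C=C4\SC(=O)N(Cc5cc(OC)c(OC)c(OC)c5)C4=O)ccc3[nH]2)cc1OC` is not yet measured. It differs from compound 3 in one place: hydrogen in place of methoxy on an aromatic carbon, a hydrogen in place of a methoxy on an aromatic carbon. Among the compounds with values here, no measured step bears directly on this change; compound 1 carries the dimethoxyphenyl and compound 2 the trimethoxyphenyl, but they also differ on the ring nitrogen, so their values show only that both sit in a similar range. Within the data shown here, with no step addressing this change, the expectation is a step of a 1.2-fold higher number from compound 3 to compound 4 (0.09 log units; within the scatter) in this assay, which is small. Compound 4 is therefore estimated at 1200 nM, in a range from 500 nM to 3000 nM.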

Compound 4, half-maximal inhibitory concentration: 270 nM
For compound 4 the middle estimate is 4.4-fold (0.65 log units) above the measured one; measured number outside the range, below it.
By their numbers in this assay, from the lowest: compound 4; then compound 3; then compounds 1 and 2 (each within the scatter of the next).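

In this assay, going by these compounds alone, taking one methoxy off the 3,4,5-trimethoxyphenyl on the shared core to leave 3,4-dimethoxyphenyl gives a 3.6-fold lower number from compound 3 to compound 4 (0.56 log units; beyond the scatter), the first measured step for a change on this aryl group, and it shows that this aromatic carbon, ortho to a methoxy group, is not a silent position. With 3,4-dimethoxyphenyl held on the core, replacing (morpholin-4-yl)carbonyl with 3,4,5-trimethoxyphenyl on the saturated chain carbon gives a 12-fold lower number from compound 1 to compound 4 (1.09 log units; beyond the scatter), which points the same way as a 3.7-fold lower number from compound 2 to compound 3 (0.57 log units; beyond the scatter), where the trimethoxyphenyl core carries (piperidin-1-yl)carbonyl as the group replaced. Nothing measured here accounts for either step.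

The compounds shown leave open whether the methoxy-to-hydrogen step would keep its direction and size with (morpholin-4-yl)carbonyl or (piperidin-1-yl)carbonyl on the chain carbon, since each of those groups appears with only one aryl group on the core. They also leave open how this aromatic carbon would respond to a hydroxy group, a fluorine atom or an ethoxy group in place of the hydrogen, and what removing either remaining methoxy would do.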